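A few compounds are considered here, and "the series" means these few. Any claim that something is new, unique, unknown or untested is made for them only; others in the source may bear on it.

Compound 1 `C/C(=C\CC/C(C)=C/CC[C@@H]1[C@@]2(C)CCC(=O)C(C)(C)[C@H]2CC[C@@]1(C)O)CC/C=C(\C)C(=O)OCc1cn(-c2cccc(Cl)c2)nn1`: 147000 nM
Compound 2 `C/C(=C\CC/C(C)=C/CC[C@@H]1[C@@]2(C)CCC(=O)C(C)(C)[C@H]2CC[C@@]1(C)O)CC/C=C(\C)C(=O)OCc1cn(-c2ccc(C)cc2)nn1`: > 150000 nM

In a functional assay on A549 cells (Homo sapiens) for antiproliferative activity, read by MTT assay, with a stated time of 48 h (a lower number here means a stronger inhibitor, a higher number a weaker inhibitor), compound 1 gives 147000 nM. For compound 2 the same assay reports only a limit, > 150000 nM. Within the data shown here, the single step between the measured pair, an at least 1.0-fold higher number from compound 1 to compound 2 (0.00 log units; that floor lies within the scatter), cannot be sized more closely, and the limit of > 150000 nM in this assay, at which 1 of the 2 values shown sits, marks where compound 2 sits. Compound 2 therefore stands at the weak edge of what these two compounds show, without a number of its own.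

Compound 3 `C/C(=C\CC/C(C)=C/CC[C@@H]1[C@@]2(C)CCC(=O)C(C)(C)[C@H]2CC[C@@]1(C)O)CC/C=C(\C)C(=O)OCc1cn(-c2cccc(C(F)(F)F)c2)nn1` has not yet been measured. The change from compound 2 to compound 3 is 3-(trifluoromethyl)phenyl in place of 4-methylphenyl on an aromatic nitrogen. Among the measured compounds shown here, only the step of an at least 1.0-fold higher number from compound 1 to compound 2 (0.00 log units; that floor lies within the scatter) bears on this change, and it tells no more than that one exchange of the aryl group on the aromatic nitrogen left the reading in this assay at its limit. No step beyond the scatter is expected in this assay. The step meant here is expected to be a step that the limit leaves unreadable from compound 2 to compound 3. Compound 3 is estimated at 160000 nM, with a range from 80000 nM to 320000 nM, and a fair chance that the assay again reports only a limit.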

Compound 3, half-maximal inhibitory concentration: > 150000 nM
Compound 3: only a limit was reported (the forecaster's own chance of this, stated with the estimate: 60%); the middle value is on the limit's open side.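

this assay now holds a second compound at its limit, since compound 3, like compound 2, is reported only as a limit and not as a number: the limit of > 150000 nM in this assay, at which 2 of the 3 values shown sit.

Among these compounds, with the aryl group kept at the same place on the aromatic nitrogen, trifluoromethyl in place of chloro on an aromatic carbon gives an at least 1.0-fold higher number from compound 1 to compound 3 (0.00 log units; that floor lies within the scatter), so this exchange shows no separation that can be read, and the earlier compounds had not tested it. The step between the two compounds held at the limit cannot be read.

The compounds shown leave open whether any change to this aryl group can bring a reading clear of the limit in this assay, as all three carry only a chloro, methyl or trifluoromethyl group on the phenyl. Whether an amine or a carboxylic acid on that phenyl would do so remains unanswered.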